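Fresh Amine at the Variable Aromatic Carbon

The compounds below may be only part of what the source reports. "The series", "measured", "known", "first", "only" and "open" are said of these compounds alone.

Three compounds sharing one core differ only in the group attached to one aromatic carbon. Compound 1 `Cc1ccc(Cl)cc1Nc1nc(C(F)(F)F)ccc1CNC(=O)C(C)c1ccc(NS(C)(=O)=O)c(F)c1` carries a (5-chloro-2-methylphenyl)amino group there, and in a functional assay on CHO-K1 cells for antagonist activity at transient receptor potential cation channel subfamily V member 1 (Homo sapiens), read by FLIPR (on this read-out lower numbers stand for stronger inhibition and higher numbers for weaker inhibition), compound 1 gives 14 nM. Compound 2 `CCCCN(C)c1nc(C(F)(F)F)ccc1CNC(=O)C(C)c1ccc(NS(C)(=O)=O)c(F)c1`, bearing butyl(methyl)amino, gives 0.8 nM in this assay, while compound 3 `CC(C(=O)NCc1ccc(C(F)(F)F)nc1N1CCC(=O)CC1)c1ccc(NS(C)(=O)=O)c(F)c1`, bearing 4-oxopiperidin-1-yl, gives 91 nM. Compound 3 thus stands at the highest number of the three: a 6.5-fold higher number from compound 1 to compound 3 (0.81 log units; beyond the scatter), and a 110-fold higher number from compound 2 to compound 3 (2.06 log units; beyond the scatter). Compound 4 `CC(C(=O)NCc1ccc(C(F)(F)F)nc1N1CCN(C2CCCCC2)CC1)c1ccc(NS(C)(=O)=O)c(F)c1` is the next step from compound 3: 4-cyclohexylpiperazin-1-yl in place of 4-oxopiperidin-1-yl on an aromatic carbon. Among the compounds with values here, the steps that bear on this change are those at the same aromatic carbon, an 18-fold lower number from compound 1 to compound 2 (1.24 log units; beyond the scatter) and a 110-fold higher number from compound 2 to compound 3 (2.06 log units; beyond the scatter), which show that the group at this position moves the read-out across a wide span, with the 4-oxopiperidin-1-yl compound at the weak end. No 4-cyclohexylpiperazin-1-yl group has been measured here, so the account expects a sizeable step downward in this assay, a 9.1-fold lower number from compound 3 to compound 4 (0.96 log units; beyond the scatter), without reaching the number of compound 2. Compound 4 is accordingly estimated at 10 nM, within a range of 2 nM to 60 nM.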

Compound 4, inhibition constant: 21.6 nM
Compound 4: middle estimate off by 2.2-fold (0.33 log units), on the low side; the measured number falls inside the stated range.
By their numbers in this assay, from the lowest: compound 2; then compounds 1 and 4 (each within the scatter of the next); then compound 3.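

In this assay, exchanging 4-oxopiperidin-1-yl for 4-cyclohexylpiperazin-1-yl at this aromatic carbon gives a 4.2-fold lower number from compound 3 to compound 4 (0.62 log units; beyond the scatter), so a saturated ring attached through its nitrogen is not tied to the weak end of the span seen so far, and what the ring carries matters. The new group still stays well short of the open-chain butyl(methyl)amino group, with a 27-fold higher number from compound 2 to compound 4 (1.43 log units; beyond the scatter), while it cannot be told apart from the (5-chloro-2-methylphenyl)amino group, with a 1.5-fold higher number from compound 1 to compound 4 (0.19 log units; within the scatter), so two quite different groups now share the middle of the series and compound 2 remains alone at the low end. Nothing in the material at hand offers a measured reason for any of these differences.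

What remains open is which part of the new group accounts for the step from the ketone-bearing ring, the cyclohexyl ring or the piperazine ring. A 4-methylpiperazin-1-yl or a plain piperidin-1-yl group at this carbon would bear on that question, and a longer chain on the nitrogen, such as hexyl(methyl)amino, would show how far the open-chain amines extend the low end.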